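A few compounds are considered here, and "the series" means these few. Any claim that something is new, unique, unknown or untested is made for them only; others in the source may bear on it.

Working notes on the series. In an assay on brain for displacement of a labelled ligand from D(3) dopamine receptor (Rattus norvegicus) (on this read-out higher numbers stand for weaker inhibition and lower numbers for stronger inhibition), compound 1 `CCCN(CC[C@H]1CC[C@H](NC(=O)/C=C/c2ccc(Cl)cc2)CC1)[C@H]1CCc2nc(N)sc2C1` gives 2.5 nM, compound 2 `CCCN(CC[C@H]1CC[C@H](NC(=O)/C=C/c2ccccc2Cl)CC1)[C@H]1CCc2nc(N)sc2C1` gives 1.2 nM, and compound 3 `CCCN(CC[C@H]1CC[C@H](NS(=O)(=O)c2ccc(OC)cc2)CC1)[C@H]1CCc2nc(N)sc2C1` gives 0.78 nM. Compound 3 holds the smallest of the three numbers, but the gap a 1.5-fold lower number from compound 2 to compound 3 (0.19 log units; within the scatter) lies within the scatter, while a 3.2-fold lower number from compound 1 to compound 3 (0.51 log units; beyond the scatter) lies beyond it. The step of a 2.1-fold lower number from compound 1 to compound 2 (0.32 log units; beyond the scatter) moves the chlorine on the aryl of the amide.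

Compound 4 `CCCN(CC[C@H]1CC[C@H](NS(=O)(=O)c2ccc(C(C)(C)C)cc2)CC1)[C@H]1CCc2nc(N)sc2C1` differs from compound 3 by tert-butyl in place of methoxy on an aromatic carbon. No measured step varies the group para to a large group on the sulfonyl aryl, so nothing shown bears directly on this change. A step within the scatter is therefore expected, a 1.3-fold higher number from compound 3 to compound 4 (0.11 log units; within the scatter), in no firm direction. For compound 4 the estimate in this assay is 1 nM, between 0.3 nM and 3.5 nM.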

Compound 4, inhibition constant: 5 nM
Compound 4: middle estimate off by 5.0-fold (0.70 log units), on the low side; the whole stated range lies below it.
By their numbers in this assay, from the lowest: compounds 3 and 2 (each within the scatter of the next); then compounds 1 and 4 (each within the scatter of the next).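

In this assay the group on the sulfonyl aryl does matter: the step of a 6.4-fold higher number from compound 3 to compound 4 (0.81 log units; beyond the scatter) is beyond the scatter and is the only step shown that keeps the sulfonyl and varies its aryl. The change replaces methoxy, with its hydrogen-bond acceptor, by tert-butyl, with none and with more heavy atoms, so this single step cannot separate the two differences. Nothing given here explains the step.

On these data alone, whether a fluorine, an amine or a carboxylic acid at this place would stay close to compound 3 remains open. So does whether tert-butyl would give a similar step on the aryl of the amides.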